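The source may hold more compounds than are shown below. What is called first, only, known or untested is meant among the compounds shown, and "the series" means these compounds.

The study rests on a shared core, carried by compound 1 `COc1cccc(Cc2ccc(-c3csc(N)n3)cc2)c1`, compound 2 `COc1ccc(Cc2ccc(-c3csc(N)n3)cc2)cc1` and compound 3 `Cc1cccc(Cc2ccc(-c3csc(N)n3)cc2)c1`. In an assay on cells for activation of leukotriene A-4 hydrolase (Homo sapiens), with a stated time of 10 min (on this read-out higher numbers stand for an effect only at larger amounts of compound and lower numbers for an effect already at smaller amounts), compound 1 gives 5920 nM. Compound 2 is built from the same atoms as compound 1, joined differently; the difference between the two cores is not broken down here. In this assay compound 2 gives 210 nM, the lowest of the three numbers, and the other two compounds stand beyond the scatter from it. Compound 3 differs from compound 1 in one place, (methyl in place of methoxy on an aromatic carbon). In this assay compound 3 gives 4810 nM, so that the step from the methoxy compound to the methyl compound is a 1.2-fold lower number from compound 1 to compound 3 (0.09 log units; within the scatter).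

Compound 4 `Cc1ccc(Cc2ccc(-c3csc(N)n3)cc2)cc1` has not yet been measured in this assay. It differs from compound 2 in one place, (methyl in place of methoxy on an aromatic carbon). Going by the values given here, this is the same kind of change as the one from compound 1 to compound 3, but not the same change: in the earlier pair the group sits meta to a large group, in the new pair para to a large group. Because the earlier step of a 1.2-fold lower number from compound 1 to compound 3 (0.09 log units; within the scatter) stayed within the scatter, a step of similar size is expected here, namely a 1.4-fold higher number from compound 2 to compound 4 (0.15 log units; within the scatter). For compound 4 the estimate in this assay is therefore 300 nM, with a range from 100 nM to 900 nM.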

Compound 4, concentration for half-maximal activity: 83 nM
Beside the measured number, compound 4's estimate is 3.6-fold (0.56 log units) above it, outside the stated range (below it).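

In this assay, methyl in place of methoxy on the aromatic carbon para to a large group gives a 2.5-fold lower number from compound 2 to compound 4 (0.40 log units; beyond the scatter), a modest step that lies beyond the scatter, whereas the same change on the core of compound 1 did not. Even so, the two steps cannot be told apart, so within this small set the change carries from one core to the other without a measurable difference in its size: the same change on two cores in this assay, a 1.2-fold lower number (0.09 log units; within the scatter) from compound 1 to compound 3 and a 2.5-fold lower number (0.40 log units; beyond the scatter) from compound 2 to compound 4, 2.1-fold (0.31 log units) apart, within the scatter of two such steps This does not show that the change has the same effect on both cores, since only two pairs are at hand and only one of the two steps lies beyond the scatter, and it says nothing about how the change would behave on any core other than these two.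

The compounds shown leave open how other groups at the same place would compare with methyl and methoxy, for example ethyl, a chlorine atom, an amine or a carboxylic acid. They also leave open how the number would move if an oxygen atom or a carbonyl took the place of the single carbon that links the two aromatic rings of the shared core.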